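Tert-Butoxycarbonyl Replaces Butyl in a Cytotoxicity Series

The compounds below may be only part of what the source reports. "The series", "measured", "known", "first", "only" and "open" are said of these compounds alone.

Of the compounds shown here, three sharing one core have been tested in a functional assay on SV5A8 cells (Homo sapiens) for cytotoxicity; a lower number here means a stronger inhibitor, a higher number a weaker inhibitor. Compound 1 `COc1ccc(CN2CCC(C(=O)Nc3ccc(CNc4nc(N(C)C)nc5cc(C)ccc45)cc3)CC2)cc1` gives only a limit there, > 6180 nM. Compound 2 `Cc1ccc2c(NCc3ccc(NC(=O)C4CCN(Cc5cccc(F)c5)CC4)cc3)nc(N(C)C)nc2c1` likewise gives only a limit, > 4170 nM. Compound 3 `CCCCN1CCC(C(=O)Nc2ccc(CNc3nc(N(C)C)nc4cc(C)ccc34)cc2)CC1` also gives only a limit, > 10500 nM. All three values are limits, so the steps a step that the two limits leave unreadable from compound 1 to compound 2, a step that the two limits leave unreadable from compound 1 to compound 3 and a step that the two limits leave unreadable from compound 2 to compound 3 have no readable size. Compound 3 thus stands at the limit of > 10500 nM in this assay, at which 1 of the 3 values shown sits, while the two other values shown sit at the limit of > 6180 nM in this assay, at which 1 of the 3 values shown sits, and (the limit of > 4170 nM in this assay, at which 1 of the 3 values shown sits).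

Compound 4 `Cc1ccc2c(NCc3ccc(NC(=O)C4CCN(C(=O)OC(C)(C)C)CC4)cc3)nc(N(C)C)nc2c1` differs from compound 3 by tert-butoxycarbonyl in place of butyl on an amine nitrogen in a ring. The three measured steps all exchange groups on a saturated chain carbon bound to the amine nitrogen in the ring, close to the place changed here, yet none of them yielded a number, so they offer no direction or size to carry over. The expected step of an at least 1.0-fold lower number from compound 3 to compound 4 (0.02 log units; that floor lies within the scatter) is therefore estimated as none beyond the scatter, with a limit again the most likely outcome. For compound 4 the estimate in this assay is 10000 nM, expected to lie between 3000 nM and 40000 nM.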

Compound 4, half-maximal inhibitory concentration: > 4820 nM
Compound 4: only a limit was reported; the forecaster's own chance of this, stated with the estimate: 80%; the middle value does not contradict the limit.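

In this assay compound 4 gives only a limit, > 4820 nM. Among the compounds shown here, compound 1, compound 2 and compound 3 also give only limits, so no step to compound 4 can be read. As far as these compounds go, whether tert-butoxycarbonyl, butyl, 3-fluorobenzyl or 4-methoxybenzyl on the amine nitrogen in the ring changes the number in this assay stays open.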